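The source may hold more compounds than are shown below. What is called first, only, known or untested is meant among the compounds shown, and "the series" means these compounds.

Measured compounds:
Compound 1, `N#Cc1ccc(Cn2cncc2CN(C(=O)c2ccccc2)c2ccc(N3CCN(C(=O)c4ccc(Cl)s4)CC3)cc2)cc1`, gives 3 nM in a functional assay on DLD-1 cells (Homo sapiens); a higher number here means a weaker inhibitor, a lower number a stronger inhibitor.
Compound 2, `COc1cccc(C(=O)N(Cc2cncn2Cc2ccc(C#N)cc2)c2ccc(N3CCN(C(=O)c4ccc(Cl)s4)CC3)cc2)c1`, gives 7 nM in this assay.

For the measured compounds named here, compound 2 stands at the higher of the two numbers measured so far; its nearest neighbour, compound 1, sits lower by a 2.3-fold higher number from compound 1 to compound 2 (0.37 log units; beyond the scatter), a modest step. The two compounds differ by a methoxy in place of a hydrogen on the aromatic ring attached to the carbonyl.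

Compound 3, `COc1ccc(C(=O)N(Cc2cncn2Cc2ccc(C#N)cc2)c2ccc(N3CCN(C(=O)c4ccc(Cl)s4)CC3)cc2)cc1`, differs from compound 2 by 4-methoxyphenyl in place of 3-methoxyphenyl on a carbonyl carbon. Going by the values given here, no measured step shows what moving a methoxy around this ring does: the only step available, from compound 1 to compound 2, concerns adding the methoxy, not relocating it. The expectation therefore rests on the small size of that addition step. In this assay the number for compound 3 is expected to stay close to that of compound 2, with a step of no change at the digits printed from compound 2 to compound 3 (within the scatter) that lies within the scatter; the estimate for compound 3 is 7 nM, with a range from 3 nM to 20 nM.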

Compound 3, half-maximal inhibitory concentration: 80 nM
Beside the measured number, compound 3's estimate is 11-fold (1.06 log units) below it; the measured number lies above the stated range.
By their numbers in this assay, from the lowest: compound 1; then compound 2; then compound 3.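

Compounds 2 and 3 have the same atoms, yet relocating the methoxy on this ring gives an 11-fold higher number from compound 2 to compound 3 (1.06 log units; beyond the scatter) in this assay so the place of the group matters, not just its presence. Adding the methoxy as 4-methoxyphenyl gives a 27-fold higher number from compound 1 to compound 3 (1.43 log units; beyond the scatter) whereas adding it as 3-methoxyphenyl gives only a 2.3-fold higher number from compound 1 to compound 2 (0.37 log units; beyond the scatter) so this ring accepts the same group far less well at one place than at the other. Nothing available here explains this gap.

The three compounds cannot show whether the loss belongs to the methoxy itself or would follow any group at that place. A fluorine, an amine or an ethoxy chain in place of the methoxy of the 4-methoxyphenyl would remain to be compared.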